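Working notes: cell tolerance of three measured compounds, one estimate

The compounds below may be only part of what the source reports. "The series", "measured", "known", "first", "only" and "open" are said of these compounds alone.

Measured compounds:
compound 1 `CCCSc1nc(Cc2c(F)cccc2Cl)cc(=O)[nH]1`: > 80000 nM
compound 2 `CCCSc1nc(C(C)c2c(F)cccc2Cl)cc(=O)[nH]1`: > 75000 nM
compound 3 `Cc1c(C(C)c2c(F)cccc2Cl)nc(SC(C)C)[nH]c1=O`: > 15000 nM

Every value in an ADME assay on MT4 cells (Homo sapiens) for activation, read by MTT assay (a higher number here means that more compound is tolerated, a lower number that less compound is tolerated), is a limit of the assay, not a number. Compound 1 sits at the limit (the limit of > 80000 nM in this assay, at which 1 of the 3 values shown sits). Compound 2 sits at the limit (the limit of > 75000 nM in this assay, at which 1 of the 3 values shown sits). Compound 3 sits at the limit (the limit of > 15000 nM in this assay, at which 1 of the 3 values shown sits).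

The change methyl in place of hydrogen on a saturated chain carbon bound to two aromatic carbons gives a step that the two limits leave unreadable from compound 1 to compound 2. The difference between the core of compound 1 and the core of compound 3 is not broken down here.

Compound 4 `CCC(c1nc(SC(C)C)[nH]c(=O)c1C)c1c(F)cccc1Cl` carries methyl in place of hydrogen on a saturated chain carbon, two bonds along the chain from two aromatic carbons against compound 3; the place is two bonds along the chain from the two aromatic carbons rather than bound to them, so it is the same kind of change, not the same.

The expected step is a step that the limit leaves unreadable from compound 3 to compound 4, resting on the unreadable step that the two limits leave unreadable from compound 1 to compound 2. Compound 4 is expected to give 30000 nM, between 8000 nM and 100000 nM, most likely reported again as a limit.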

Compound 4, half-maximal cytotoxic concentration: > 3000 nM
Compound 4: a limit, no number; the forecaster's own chance of this, stated with the estimate: 60%; the middle value does not contradict the limit.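

In this assay compound 3 stands only as a limit, > 15000 nM. For the compounds shown here, compound 4 is also only a limit, > 3000 nM, and no step between compound 3 and compound 4 can be read. The compounds shown leave open whether methyl in place of hydrogen on the chain changes tolerance at all.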